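Indole vinyl sulfones: methoxy removal at the fused benzene ring

The source may report more compounds than this note shows. Statements on the series, on what has been measured and on what is new or still open speak of the compounds shown alone.

Measured compounds:
- compound 1 `O=C(/C(=C\c1c(-c2ccccc2)[nH]c2ccccc12)S(=O)(=O)c1ccccc1)c1ccccc1` — "not determined" (no result reported) in a functional assay on MOLT-4 cells (Homo sapiens) for inhibition, read by sulforhodamine B assay, with a stated time of 48 h; a higher number here means a weaker inhibitor of growth, a lower number a stronger inhibitor of growth
- compound 2 `COc1ccc2[nH]c(-c3ccccc3)c(/C=C(\C#N)S(=O)(=O)c3ccccc3)c2c1` — 4700 nM

For the measured compounds named here, compound 2 is the only compound of the set with a number in this assay; compound 1, which carries a benzoyl group in place of the nitrile on the exocyclic double bond, was run without a reported result. Compound 2 therefore stands alone and cannot be ranked against anything.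

The next compound, compound 3 `N#C/C(=C\c1c(-c2ccccc2)[nH]c2ccccc12)S(=O)(=O)c1ccccc1`, keeps the nitrile, the phenylsulfonyl group and the phenyl-substituted core of compound 2 and differs from it in one place: hydrogen in place of methoxy on an aromatic carbon. Going by the values given here, no pair of measured compounds shows what this change does, so the size of the step is unknown from the data.

With nothing to go on beyond compound 2 itself, the step in this assay is expected to be small, not beyond the scatter in either direction, a 1.1-fold higher number from compound 2 to compound 3 (0.03 log units; within the scatter). For compound 3 a value of about 5000 nM is estimated, with a range from 1800 nM to 14000 nM.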

Compound 3, concentration for 50% growth inhibition: 2200 nM
Estimate against measurement, compound 3: 2.3-fold (0.36 log units) above; measured number inside the range.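

In this assay, hydrogen in place of methoxy on this aromatic carbon gives a 2.1-fold lower number from compound 2 to compound 3 (0.33 log units; beyond the scatter) and thus a modest move towards stronger inhibition of growth. For the compounds shown here, this is the first readable step, and it shows that the methoxy at this place on the fused system, meta to one fused ring and para to the other, is not needed for the growth inhibition seen with compound 2; the unsubstituted carbon does better here, though only by a modest margin. No measurement at hand accounts for the size or direction of this step.

The compounds shown leave open how a fluorine, a hydroxy group or an amine on this same carbon would compare with hydrogen and methoxy, and whether the step holds at any other carbon of the shared core. The exchange of nitrile for benzoyl on the exocyclic double bond cannot be read: compound 1 gives "not determined" (no result reported) in this assay and so offers no number to set against compound 3.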